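Methoxy to Ethoxy: A Small Step Awaited

This account rests on a few compounds, and the source may have more. Where it says the series, first, only, none or still open, it means among the compounds named here.

Of the compounds shown here, three have been measured in a functional assay on MCF7 cells (Homo sapiens) for cytotoxicity, read by MTT assay, with a stated time of 48 h; a lower number here means a stronger inhibitor, a higher number a weaker inhibitor. Compound 3 `COc1ccc(NC(=O)c2cn(-c3ccccc3)nc2-c2ccc([N+](=O)[O-])cc2)cc1` gives 1210 nM in this assay. Of the three numbers this is the second highest; its nearest neighbour is compound 1 `CCOc1ccc(NC(=O)c2cn(-c3ccccc3)nc2-c2ccc(C)cc2)cc1`, which gives 1030 nM, and the furthest is compound 2 `O=C(Nc1ccccc1)c1cn(-c2ccccc2)nc1-c1ccc([N+](=O)[O-])cc1`, which gives 2260 nM. Both gaps lie within the scatter, so the three compounds cannot be set apart on these numbers.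

Within the data shown here, the only step between compounds that differ in a single place is a 1.9-fold lower number from compound 2 to compound 3 (0.27 log units; within the scatter), and it too stays within the scatter.

Compound 4 `CCOc1ccc(NC(=O)c2cn(-c3ccccc3)nc2-c2ccc([N+](=O)[O-])cc2)cc1` has not yet been measured. It differs from compound 3 by methyl in place of hydrogen on a saturated chain carbon bound to an oxygen on an aromatic ring. Among the measured compounds shown here, no measured pair covers this exact change. For the measured compounds named here, compound 1 also carries an ethoxy group, but it differs from compound 3 in a second place as well, so the two values show only that these two compounds sit within the scatter of one another. Going by the values given here, with the single measured step within the scatter and no direct precedent, compound 4 is expected to show a step of a 1.1-fold lower number from compound 3 to compound 4 (0.04 log units; within the scatter) in this assay, which amounts to nothing beyond the scatter. The estimate for compound 4 is 1100 nM, with a range from 500 nM to 2500 nM.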

Compound 4, half-maximal inhibitory concentration: 460 nM
The estimate for compound 4 lay 2.4-fold (0.38 log units) above the measured number, outside the stated range (below it).
By their numbers in this assay, from the lowest: compound 4; then compounds 1, 3 and 2 (each within the scatter of the next, the first and the last beyond it).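

In this assay, the single added methyl on the saturated chain carbon bound to an oxygen on an aromatic ring goes with a real change (a 2.6-fold lower number from compound 3 to compound 4 (0.42 log units; beyond the scatter)), so this position responds to methoxy to ethoxy in a way the earlier numbers could not show. Measured against hydrogen on the same aromatic carbon, ethoxy also stands beyond the scatter (a 4.9-fold lower number from compound 2 to compound 4 (0.69 log units; beyond the scatter)), whereas methoxy in that place stayed within it (a 1.9-fold lower number from compound 2 to compound 3 (0.27 log units; within the scatter)). Among these compounds, with ethoxy held constant, the other aromatic substituent proves to count as well: nitro in place of methyl gives a step beyond the scatter (a 2.2-fold lower number from compound 1 to compound 4 (0.35 log units; beyond the scatter)), a difference that no earlier pair could isolate. Nothing in the information available explains why these changes alter the cytotoxicity readings.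

The compounds shown leave open whether a longer chain, such as propoxy, or a branched isopropoxy would extend or reverse the methoxy to ethoxy step, since that step stands on one pair alone. They also leave open whether an amine or a chlorine in place of the nitro would keep the lower number seen with compound 4.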